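Notes on a chloro for fluoro swap

The compounds below may be only part of what the source reports. "The series", "measured", "known", "first", "only" and "open" are said of these compounds alone.

Measured compounds (a functional assay on QGY-7703 cells (Homo sapiens) for cytotoxicity, read by MTT assay, with a stated time of 24 h; a lower number here means a stronger inhibitor, a higher number a weaker inhibitor)
- compound 1 (`Cc1ccc(S(=O)(=O)N2C/C(=C\c3ccncc3)C(=O)/C(=C/c3ccccc3C(F)(F)F)C2)cc1`) gives 5090 nM
- compound 2 (`O=C1/C(=C/c2ccncc2)CN(S(=O)(=O)c2ccc(F)cc2)C/C1=C\c1ccccc1C(F)(F)F`) gives 7700 nM

Compound 2 at 7700 nM stands within the scatter of compound 1 at 5090 nM and the two values cannot be ranked. Compound 3 (`O=C1/C(=C/c2ccncc2)CN(S(=O)(=O)c2ccc(Cl)cc2)C/C1=C\c1ccccc1C(F)(F)F`) differs from compound 2 in one place (chloro in place of fluoro on an aromatic carbon): chloro in place of fluoro on an aromatic carbon, para to a large group, which turns 4-fluorophenyl into 4-chlorophenyl.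

Among the compounds with values here, only one measured step bears on this change: fluoro in place of methyl on an aromatic carbon (a 1.5-fold higher number from compound 1 to compound 2 (0.18 log units; within the scatter)). That step stayed within the scatter. Within the data shown here, it is a single step, and no measured compound carries chloro, so the data give no direct reading of this swap. On that basis no step beyond the scatter is expected in this assay and no firm direction can be assigned. The estimated step (a 1.2-fold lower number from compound 2 to compound 3 (0.09 log units; within the scatter)) is expected to stay small. In this assay the estimate for compound 3 is 6300 nM with an expected range of 2800 nM to 14000 nM around it.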

Compound 3, half-maximal inhibitory concentration: 12700 nM
The estimate for compound 3 lay 2.0-fold (0.30 log units) below the measured number, and the stated range covers the measured number.
By their numbers in this assay, from the lowest: compounds 1, 2 and 3 (each within the scatter of the next, the first and the last beyond it).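

Read in this assay, the change of chloro for methyl gives the first step at this position that leaves the scatter, with a 2.5-fold higher number from compound 1 to compound 3 (0.40 log units; beyond the scatter), so compound 3 is modestly the weaker inhibitor of that pair. The change of chloro for fluoro gives a 1.6-fold higher number from compound 2 to compound 3 (0.22 log units; within the scatter), so compound 2 and compound 3 cannot be ranked, just as compound 1 and compound 2 could not; the three groups therefore show a separation only between the two ends of the span, with fluoro unresolved from either. No measurement at hand accounts for the gap between methyl and chloro.

Open still is how this position responds to groups of a different kind in place of the halogen or methyl, such as a methoxy group, a nitrile, an amine or a carboxylic acid. Also open, going by these compounds, is whether the modest gap between methyl and chloro on the sulfonyl-bearing aromatic ring holds once the rest of the shared core is changed, as all three compounds carry the same remaining groups.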